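Removing one methyl from compound 3

This account rests on a few compounds, and the source may have more. Where it says the series, first, only, none or still open, it means among the compounds named here.

In a functional assay on HT-29 cells (Homo sapiens) for antiproliferative activity, read by sulforhodamine B assay, with a stated time of 48 h (a lower number here means a stronger inhibitor, a higher number a weaker inhibitor), three compounds sharing one core have been measured. Compound 1 `CCc1ccc(NS(=O)(=O)c2ccc(N3CCNC3=O)cc2)cc1` gives 660 nM, compound 2 `O=C1NCCN1c1ccc(S(=O)(=O)Nc2ccc(Cl)cc2)cc1` gives 220 nM and compound 3 `Cc1cccc(NS(=O)(=O)c2ccc(N3CCNC3=O)cc2)c1C` gives 190 nM. Compound 3 sits at the low end of these numbers, level with its nearest neighbour: a 1.2-fold lower number from compound 2 to compound 3 (0.06 log units; within the scatter). Its furthest neighbour is separated by a modest gap: a 3.5-fold lower number from compound 1 to compound 3 (0.54 log units; beyond the scatter).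

Compound 4 `Cc1ccccc1NS(=O)(=O)c1ccc(N2CCNC2=O)cc1` is the next case, with 2,3-dimethylphenyl becoming 2-methylphenyl: hydrogen in place of methyl on an aromatic carbon.

Among the compounds with values here, no measured step removes a single methyl, so the evidence is indirect. The nearest guides are changes to the same aromatic substituent, and the two that exceed the scatter are both modest: a 3.0-fold lower number from compound 1 to compound 2 (0.48 log units; beyond the scatter) and the step to compound 3 already given. The third step, between compound 2 and compound 3, stays within the scatter. A large jump therefore has no support in these data. With compound 3 at 190 nM, at the low end of the range seen, a small rise is the likelier direction, although no change beyond the scatter remains possible. The step expected is a 1.8-fold higher number from compound 3 to compound 4 (0.27 log units; within the scatter). For compound 4 the estimated value is 350 nM, with an expected range of 130 nM to 900 nM.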

Compound 4, half-maximal inhibitory concentration: 200 nM
Estimate against measurement, compound 4: 1.8-fold (0.24 log units) above, and the stated range covers the measured number.
By their numbers in this assay, from the lowest: compounds 3, 4 and 2 (each within the scatter of the next); then compound 1.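

In this assay, within the data shown here, the methyl on the carbon ortho to a methyl group can go without a change beyond the scatter, with a 1.1-fold higher number from compound 3 to compound 4 (0.02 log units; within the scatter) as the first step confined to this one place, so the 2,3-dimethylphenyl pattern of compound 3 is not needed to hold its level. The 2-methylphenyl group also stands level with 4-chlorophenyl, at a 1.1-fold lower number from compound 2 to compound 4 (0.04 log units; within the scatter) for that swap on the sulfonamide nitrogen, while the gap to 4-ethylphenyl stays modest and beyond the scatter, at a 3.3-fold lower number from compound 1 to compound 4 (0.52 log units; beyond the scatter) for the other swap, which leaves compound 1 as the only one of the four apart from the rest. Nothing measured on these compounds explains why this position tolerates the loss of the methyl.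

Still open, on these data alone, is what the remaining methyl contributes, a question that a plain phenyl on the sulfonamide nitrogen would address. Also open, as far as these compounds go, is whether the same flat response would hold for an amine, a carboxylic acid or a longer chain on the aromatic carbon that now carries hydrogen.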